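A few compounds are considered here, and "the series" means these few. Any claim that something is new, unique, unknown or untested is made for them only; others in the source may bear on it.

Measured so far:
- compound 1 `Nc1scc(CN2CCN(c3ccc(Cl)cc3Cl)CC2)c1C(=O)c1ccc(Cl)cc1`: 0%
- compound 2 `COc1ccc(N2CCN(Cc3csc(N)c3C(=O)c3ccc(Cl)cc3)CC2)cc1`: 0%

In an assay on CHO cells for displacement of a labelled ligand from adenosine receptor A3 (Homo sapiens), read by scintillation counting, with a stated time of 120 min, tested at 10 uM (on this read-out lower numbers stand for less inhibition and higher numbers for more inhibition at the one concentration tested (going by the name of the read-out)), compound 1 gives 0% and compound 2 gives 0%. Among the compounds with values here, the single measured step, no change at the digits printed from compound 1 to compound 2 (within the scatter), swapped the aryl group on the ring amine nitrogen and left the read-out unchanged. Compound 2 therefore stands level with compound 1, both showing no measurable inhibition.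

Compound 3 `Nc1scc(CN2CCN(c3cccc(C(F)(F)F)c3)CC2)c1C(=O)c1ccc(Cl)cc1` differs from compound 2 in the same position: 3-(trifluoromethyl)phenyl in place of 4-methoxyphenyl on an amine nitrogen in a ring. This step bears directly on the measured one, since both exchange the aryl group on the ring nitrogen of the shared core while the rest of compound 2 is untouched. Because the earlier exchange gave no change at the digits printed from compound 1 to compound 2 (within the scatter), no shift beyond the scatter is expected here either; the estimated step is no change at the digits printed from compound 2 to compound 3 (within the scatter). Compound 3 is estimated to give 0% in this assay, with a range from 0% to 10%.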

Compound 3, a percentage reported as inhibition, at one concentration (the size of the read-out at that concentration, not a potency): 0%
For compound 3 middle estimate and measured number coincide at the digits printed; the range from low to high includes it.
By their numbers in this assay, from the lowest: compounds 1, 2 and 3 (each within the scatter of the next).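

In this assay, putting 3-(trifluoromethyl)phenyl in place of 4-methoxyphenyl on the amine nitrogen in the ring gives no change at the digits printed from compound 2 to compound 3 (within the scatter) and, in place of 2,4-dichlorophenyl, gives no change at the digits printed from compound 1 to compound 3 (within the scatter) in the same read-out. A third aryl group, which brings fluorine atoms and has no hydrogen-bond acceptor by the count given, therefore joins the other two, and none of the three shows measurable inhibition at the one concentration tested. No supporting data bear on this flat result.

With every value at the same level, these compounds cannot rank the aryl groups against one another. Still open, from the compounds shown here alone, is whether something other than a substituted phenyl on this nitrogen, such as a pyridine ring, a benzyl group or a short alkyl chain, or a change elsewhere on the shared core, would produce any inhibition.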